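The compounds below may be only part of what the source reports. "The series", "measured", "known", "first", "only" and "open" are said of these compounds alone.

Measured in a functional assay on A2780 cells (Homo sapiens) for inhibition, read by MTT assay, with a stated time of 72 h; a lower number here means a stronger inhibitor, a higher number a weaker inhibitor:
- Compound 1 `O=C1/C(=C\c2ccccc2)c2c(ncn2COCc2ccccc2)CCN1Cc1ccccc1`: 20400 nM
- Compound 2 `COc1cc(/C=C2\C(=O)N(Cc3ccccc3)CCc3ncn(COCc4ccccc4)c32)cc(OC)c1OC`: 8970 nM
- Compound 3 `O=C1/C(=C\c2ccncc2)c2c(ncn2COCc2ccccc2)CCN1Cc1ccccc1`: > 100000 nM

The entry for compound 3 is a limit of the assay and not a number. Compound 3 therefore stands only at the limit of > 100000 nM in this assay, at which 1 of the 3 values shown sits, and no exact potency can be read for it.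

Compound 4 `O=C1/C(=C\c2ccc(C(F)(F)F)cc2)c2c(ncn2COCc2ccccc2)CCN1Cc1ccccc1` has 4-(trifluoromethyl)phenyl in place of pyridin-4-yl on a double-bonded chain carbon bound to a double-bonded ring carbon. Three measured steps at this same place bear on the change. Putting pyridin-4-yl in place of phenyl gave an at least 4.9-fold higher number from compound 1 to compound 3 (0.69 log units; beyond the scatter), and putting it in place of 3,4,5-trimethoxyphenyl gave an at least 11-fold higher number from compound 2 to compound 3 (1.04 log units; beyond the scatter). The exchange between the two carbon-only rings moved the number much less, with a 2.3-fold lower number from compound 1 to compound 2 (0.36 log units; beyond the scatter).

The group entering compound 4 also has a six-membered aromatic ring of carbon only. In this assay, a clear step to a lower number is therefore expected, roughly undoing the large steps seen on introducing pyridin-4-yl. The expected change is an at least 6.2-fold lower number from compound 3 to compound 4 (0.79 log units; beyond the scatter). For compound 4 the estimated value is 16000 nM, with an expected range from 5000 nM to 50000 nM.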

Compound 4, half-maximal inhibitory concentration: 28200 nM
Estimate against measurement, compound 4: 1.8-fold (0.25 log units) below, and the stated range covers the measured number.
By their numbers in this assay, from the lowest: compound 2; then compounds 1 and 4 (each within the scatter of the next). At a limit, above all of these: compound 3.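

In this assay, a carbon-only ring that carries a substituent other than methoxy also gives a measured number, and the change away from pyridin-4-yl gives an at least 3.5-fold lower number from compound 3 to compound 4 (0.54 log units; beyond the scatter). From the compounds shown here alone, compound 3 has a limit of the assay and not a number, so the true size of this step remains unknown: the limit of > 100000 nM in this assay, at which 1 of the 4 values shown sits. Adding trifluoromethyl in place of hydrogen on an aromatic carbon keeps compound 4 within the scatter of the unsubstituted phenyl compound, with a 1.4-fold higher number from compound 1 to compound 4 (0.14 log units; within the scatter), whereas replacing 3,4,5-trimethoxyphenyl gives a 3.1-fold higher number from compound 2 to compound 4 (0.50 log units; beyond the scatter), so among the measured carbon-only rings compound 2 alone stands clearly apart from the other two.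

The compounds shown leave open whether the loss in compound 3 is tied to the ring nitrogen of pyridin-4-yl in that particular arrangement, as pyridin-3-yl would test, or would also appear with other nitrogen-containing rings such as pyrimidin-5-yl. They also leave open how a single methoxy group, an amine or a carboxylic acid on the phenyl ring would compare with trifluoromethyl and with the three methoxy groups of compound 2.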